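This account rests on a few compounds, and the source may have more. Where it says the series, first, only, none or still open, it means among the compounds named here.

Of the compounds shown here, three built on a shared core have been tested in a functional assay on MCF7 cells (Homo sapiens) for inhibition, read by sulforhodamine B assay, with a stated time of 72 h; on this read-out higher numbers stand for weaker inhibition and lower numbers for stronger inhibition. Compound 1 `CC(c1ccc(-c2ccccc2)c(F)c1)c1nnc2n1N=C(c1ccc(Cl)cc1Cl)CS2` gives 7600 nM. Compound 2 `CC(C)Cc1ccc(C(C)c2nnc3n2N=C(c2ccc(OC(F)(F)F)cc2)CS3)cc1` gives 1100 nM, the lowest of the three numbers, and its gaps to both other compounds lie beyond the scatter. Compound 3 `COc1ccc2cc(C(C)c3nnc4n3N=C(c3ccc(Br)cc3)CS4)ccc2c1` gives 11500 nM. No two of these measured compounds differ in only one place, so no single structural change can yet be tied to a step in the numbers. Compound 4 `CC(C)Cc1ccc(C(C)c2nnc3n2N=C(c2ccc(C(F)(F)F)cc2)CS3)cc1` has not been measured; it differs from compound 2 in a single place: trifluoromethyl in place of trifluoromethoxy on an aromatic carbon. Within the data shown here, nothing measured so far bears on this change, so a step of a 1.2-fold higher number from compound 2 to compound 4 (0.07 log units; within the scatter) is expected to stay within the scatter, in either direction. Compound 4 is estimated at 1300 nM, within a range from 500 nM to 3500 nM.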

Compound 4, half-maximal inhibitory concentration: 4200 nM
The estimate for compound 4 lay 3.2-fold (0.51 log units) below the measured number; measured number outside the range, above it.
By their numbers in this assay, from the lowest: compound 2; then compounds 4, 1 and 3 (each within the scatter of the next, the first and the last beyond it).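

Among these compounds, this is the first direct reading of this place, an aromatic carbon para to a large group. In this assay, trifluoromethyl in place of trifluoromethoxy gives a 3.8-fold higher number from compound 2 to compound 4 (0.58 log units; beyond the scatter) and shows that the choice of group here matters, even though the two groups differ by only one oxygen atom. No measurement at hand explains why the number moved. Going by these compounds, whether this step would carry over to other compounds on the shared core remains open, as does what a nitrile or an amine would give at this place.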